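Trimming butylcarbonyl to propanoyl in compound 3

The source may hold more compounds than are shown below. What is called first, only, known or untested is meant among the compounds shown, and "the series" means these compounds.

Compound 1 `Cn1c(=O)sc2ccccc21`: > 100 mg/kg, a limit
Compound 2 `CCC(=O)c1ccc2c(c1)sc(=O)n2CCN1CCCC1`: > 80 mg/kg, a limit
Compound 3 `CCCCC(=O)c1ccc2c(c1)sc(=O)n2CCN(C)C`: > 70 mg/kg, a limit

In a functional assay on the whole organism for inhibition, with Mus musculus as the target (on this read-out lower numbers stand for an effect already at smaller amounts and higher numbers for an effect only at larger amounts of compound), compound 3 stands at > 70 mg/kg, which is a limit and not a number. Among the measured compounds shown here, the other two values shown are limits as well, so no compound here has a measured dose. Compound 4 `CCC(=O)c1ccc2c(c1)sc(=O)n2CCN(C)C` differs from compound 3 by one change, (hydrogen in place of ethyl on a saturated chain carbon, two bonds along the chain from a carbonyl carbon), which turns butylcarbonyl into propanoyl. Compound 2 also carries propanoyl and gives > 80 mg/kg, again a limit. With only limits to go on, the expected change in this assay is a number no higher from compound 3 to compound 4 (the limit leaves the size open), with no shift in either direction beyond the scatter. For compound 4 the estimated dose is 70 mg/kg, with an expected range of 25 mg/kg to 160 mg/kg.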

Compound 4, dose for half-maximal effect: > 130 mg/kg
Compound 4: only a limit was reported (the forecaster's own chance of this, stated with the estimate: 60%); middle value at least 1.8-fold (0.26 log units) from the limit.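

Compound 4 gives only a limit, as do compound 2 and compound 3, so the steps to compound 4 from either of them cannot be read. From the compounds shown here alone, whether propanoyl in place of butylcarbonyl, or dimethylamino in place of pyrrolidin-1-yl, shifts the dose at all stays open.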